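Swapping a pyridine for a methoxyphenyl on the thioether

The source may hold more compounds than are shown below. What is called first, only, known or untested is meant among the compounds shown, and "the series" means these compounds.

Compound 1 `CC(Sc1nc2c(cnn2C)c(=O)n1-c1ccccc1)c1ccccn1` is measured in an assay on isolated protein for inhibition of aldehyde dehydrogenase 1A1 (Homo sapiens) (a lower number here means a stronger inhibitor, a higher number a weaker inhibitor), and gives 242 nM, the second highest of three numbers. Compound 3 `CC(Sc1nc2nn(C3(C)COC3)cc2c(=O)n1-c1ccccc1)c1ccccc1` gives 93 nM in this assay, and compound 2 `Cn1ncc2c(=O)n(-c3ccccc3)c(SC(C)(C)c3ccccc3)nc21` gives 1900 nM. Compound 4 `COc1cccc(C(C)Sc2nc3c(cnn3C)c(=O)n2-c2ccccc2)c1` has not yet been measured; it differs from compound 1 by 3-methoxyphenyl in place of pyridin-2-yl on a saturated chain carbon bound to a saturated chain carbon and a sulfur. Among the compounds with values here, no measured step matches this change exactly. The nearest is a 7.9-fold higher number from compound 1 to compound 2 (0.89 log units; beyond the scatter), which alters the same sulfur-bound group but also adds a methyl, so it only loosely bears on the new step. Compound 3 shows that a carbon-only ring at this carbon can sit with a lower number. On balance the expected step is small, a 1.2-fold lower number from compound 1 to compound 4 (0.08 log units; within the scatter), and compound 4 is estimated at 200 nM, between 70 nM and 700 nM.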

Compound 4, half-maximal inhibitory concentration: 451 nM
For compound 4 the middle estimate is 2.3-fold (0.35 log units) below the measured one; low and high end bracket the measured number.
By their numbers in this assay, from the lowest: compound 3; then compounds 1 and 4 (each within the scatter of the next); then compound 2.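

In this assay, 3-methoxyphenyl in place of pyridin-2-yl gives a 1.9-fold higher number from compound 1 to compound 4 (0.27 log units; within the scatter), so this change of aromatic ring at the carbon bound to the sulfur stays inside the usual scatter. The step of a 7.9-fold higher number from compound 1 to compound 2 (0.89 log units; beyond the scatter), which also adds a methyl, is by contrast beyond the scatter. Nothing available explains either result.

Open, as far as these compounds go, is what an unsubstituted phenyl on the core of compound 1 would give. Also open, from the compounds shown here alone, is how a ring carrying an amine or a carboxylic acid at this carbon would compare.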